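The source may report more compounds than this note shows. Statements on the series, on what has been measured and on what is new or still open speak of the compounds shown alone.

Measured so far:
compound 1 `COC(=O)N[C@H]1Cc2ccc(NC(=O)c3cc(C)ccc3-c3ccc(C(F)(F)F)cc3)cc2C1`; in an assay on isolated protein for inhibition of microsomal triglyceride transfer protein large subunit (Homo sapiens) (a lower number here means a stronger inhibitor, a higher number a weaker inhibitor), compound 1 gives 170 nM.
compound 2 `Cc1cccc(C(=O)Nc2ccc3c(c2)CC(NS(=O)(=O)c2ccccc2)C3)c1-c1ccc(F)cc1`; in this assay compound 2 gives 240 nM.

Among the measured compounds shown here, compound 2 and compound 1 give values that lie within the usual scatter of each other, so the numbers alone tell no difference between them; the two also differ in more than one place, so no single step connects them.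

Compound 3 `Cc1cccc(C(=O)Nc2ccc3c(c2)CC(NS(=O)(=O)c2ccccc2)C3)c1-c1ccc(Cl)cc1` differs from compound 2 in one place: chloro in place of fluoro on an aromatic carbon. For the measured compounds named here, no step between measured compounds shows what such an exchange does here. In this assay the step from compound 2 to compound 3 is expected to be a 1.1-fold lower number from compound 2 to compound 3 (0.06 log units; within the scatter), that is, none beyond the scatter. Compound 3 is therefore estimated at 210 nM, within a range from 80 nM to 550 nM.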

Compound 3, half-maximal inhibitory concentration: 100 nM
Beside the measured number, compound 3's estimate is 2.1-fold (0.32 log units) above it; the range from low to high includes it.
By their numbers in this assay, from the lowest: compounds 3, 1 and 2 (each within the scatter of the next, the first and the last beyond it).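

The exchange of 4-fluorophenyl for 4-chlorophenyl gives a 2.4-fold lower number from compound 2 to compound 3 (0.38 log units; beyond the scatter) in this assay, the first single-place step available here. It shows that this position, para to a large group, responds to a swap of one atom for another while the heavy-atom count stays the same. Nothing measured here explains the change.

Still open, on these data alone, is how a bromo, methyl or methoxy group would compare at this position. Also open, as far as these compounds go, is whether the same exchange would give a similar step with the methyl carbamate of compound 1 in place of the benzenesulfonamide.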